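Notes on the urea-to-benzylamine change at the ring nitrogen

This account rests on a few compounds, and the source may have more. Where it says the series, first, only, none or still open, it means among the compounds named here.

Compound 2 `O=C(Nc1ncc(C(=O)O)c2nc(-c3ccco3)nn12)NC1CCCCC1` is the reference point for the step considered here. In a functional assay on CHO cells for antagonist activity at adenosine receptor A2b (Homo sapiens) (a higher number here means a weaker inhibitor, a lower number a stronger inhibitor), compound 2 gives > 30000 nM, which is a limit of the assay and not a number. Compound 1 `CNC(=O)c1cnc(NC(=O)NC2CCCCC2)n2nc(-c3ccco3)nc12` gives > 30000 nM in this assay, again a limit. Compound 3 `CCOC(=O)c1cnc(NC2CCCCC2)n2nc(-c3ccco3)nc12` gives > 10000 nM in this assay, also a limit. For the measured compounds named here, two of the three values sit at the limit of > 30000 nM in this assay, at which 2 of the 3 values shown sit, and one at the limit of > 10000 nM in this assay, at which 1 of the 3 values shown sits, and the only step between measured compounds, a step that the two limits leave unreadable from compound 1 to compound 2, is unreadable.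

Compound 4 `O=C(O)c1cnc(NCc2ccc(Cl)cc2)n2nc(-c3ccco3)nc12` differs from compound 2 by 4-chlorobenzyl in place of cyclohexylcarbamoyl on a nitrogen on an aromatic ring. Going by the values given here, no measured step bears on this change: compound 3 carries an amine rather than a urea on that nitrogen, but it also differs from compound 2 at the carbonyl substituent, and both of those values are limits, so the size of an amine-for-urea step cannot be read. Compound 4 is accordingly expected to give 12000 nM in this assay, with a likely range of 1500 nM to 60000 nM. The step of an at least 2.5-fold lower number from compound 2 to compound 4 (0.39 log units; beyond the scatter) is expected to stay within the scatter, with a fair chance that compound 4 also returns only a limit.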

Compound 4, inhibition constant: > 30000 nM
Compound 4: a limit, no number; the forecaster's own chance of this, stated with the estimate: 55%; at least 2.5-fold (0.39 log units) between middle value and limit.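

In this assay compound 4 gives > 30000 nM, a limit and not a number. Compound 2 also stands at a limit, and the step between compound 2 and compound 4 cannot be read. The compounds shown leave open how 4-chlorobenzyl and cyclohexylcarbamoyl compare on that nitrogen, as none of them returns a number.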